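The compounds below may be only part of what the source reports. "The series", "measured", "known", "first", "only" and "open" are said of these compounds alone.

Measured compounds:
- compound 1, `C[C@H](NC(=O)c1c(C(F)(F)F)nnn1Cc1cccc(C(F)(F)F)c1)c1ccc(C(=O)O)cc1` — 1970 nM
- compound 2, `C[C@H](NC(=O)c1c(-c2ccccc2)nnn1Cc1ccccc1)c1ccc(C(=O)O)cc1` — 647 nM
- compound 3, `C[C@H](NC(=O)c1c(-c2ccccc2)nnn1Cc1cccc(C(F)(F)F)c1)c1ccc(C(=O)O)cc1` — 23 nM

Of the compounds shown here, three sharing one core have been measured in a functional assay on CHO cells for antagonist activity at prostaglandin E2 receptor EP4 subtype (Homo sapiens), read by calcium flux, with a stated time of 15 min; a higher number here means a weaker inhibitor, a lower number a stronger inhibitor. Compound 3 gives the lowest of the three numbers; its nearest neighbour is compound 2, reached by a 28-fold lower number from compound 2 to compound 3 (1.45 log units; beyond the scatter), and the furthest is compound 1, reached by an 86-fold lower number from compound 1 to compound 3 (1.93 log units; beyond the scatter). Compound 4, `COc1cccc(Cn2nnc(-c3ccccc3)c2C(=O)N[C@@H](C)c2ccc(C(=O)O)cc2)c1`, has not yet been measured in this assay. It differs from compound 3 in one place: methoxy in place of trifluoromethyl on an aromatic carbon.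

For the measured compounds named here, the step that bears on this change is the one from compound 2 to compound 3, in which the same aromatic carbon carried hydrogen and then trifluoromethyl, and the number fell sharply. Going by the values given here, no measured pair shows methoxy at that position. Compound 4 keeps a substituent there, but not the one that produced the large gain, so a loss relative to compound 3 is expected, though a smaller one than the return to hydrogen seen in compound 2. Compound 4 is therefore estimated at 150 nM, within a range of 40 nM to 600 nM, which means an expected step of a 6.5-fold higher number from compound 3 to compound 4 (0.81 log units; beyond the scatter).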

Compound 4, half-maximal inhibitory concentration: 96.8 nM
For compound 4 the middle estimate is 1.5-fold (0.19 log units) above the measured one; low and high end bracket the measured number.
By their numbers in this assay, from the lowest: compound 3; then compound 4; then compound 2; then compound 1.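

In this assay, a second substituent on this aromatic carbon now has a measured value, and the drop in the number relative to hydrogen is not confined to trifluoromethyl: methoxy also gives a clear improvement (a 6.7-fold lower number from compound 2 to compound 4 (0.83 log units; beyond the scatter)). Trifluoromethyl nevertheless remains ahead of methoxy (a 4.2-fold higher number from compound 3 to compound 4 (0.62 log units; beyond the scatter)), so the result at this position depends on which group is present as well as on whether a substituent is present at all. No available evidence accounts for the difference between the two groups.

The compounds shown leave open how other groups on this carbon, such as an amine, a chlorine atom or a longer chain like ethoxy, would compare. They also leave open whether methoxy would keep its standing if trifluoromethyl replaced the phenyl on the shared core.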